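The source may report more compounds than this note shows. Statements on the series, on what has been measured and on what is new or still open speak of the compounds shown alone.

Compound 1 `COc1ccccc1-c1ccccc1O`: 54 ug/mL
Compound 2 `Nc1ccccc1-c1ccccc1O`: 54.1 ug/mL
Compound 3 `COc1cccc(-c2ccc(O)cc2)c1`: 35 ug/mL

These three compounds were tested in an ADME assay on HEK293 cells (Homo sapiens) for cytotoxicity, read by MTT assay, with a stated time of 3 days; a lower number here means a stronger inhibitor, a higher number a weaker inhibitor. Compound 1 and compound 2 differ in one place, (amino in place of methoxy on an aromatic carbon), and that change made a 1.0-fold higher number from compound 1 to compound 2 (0.00 log units; within the scatter). Compound 3 is built on a different core, and the difference between the two cores is not broken down here. Compound 4 `Nc1cccc(-c2ccc(O)cc2)c1` has not yet been measured in this assay. It is related to compound 3 by the same kind of change, (amino in place of methoxy on an aromatic carbon); in the first pair the group is ortho to a group of 7 heavy atoms, here it is meta to a group of 7 heavy atoms. Because the same kind of change gave a 1.0-fold higher number from compound 1 to compound 2 (0.00 log units; within the scatter) in the first pair, the expected step is no change at the digits printed from compound 3 to compound 4 (within the scatter). Compound 4 is therefore estimated at 35 ug/mL, with a likely range from 20 ug/mL to 70 ug/mL.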

Compound 4, half-maximal inhibitory concentration: > 100 ug/mL
Compound 4 was reported as a limit (the forecaster's own chance of this, stated with the estimate: 5%); middle value at least 2.8-fold (0.45 log units) from the limit.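

In this assay, amino in place of methoxy gave an at least 2.8-fold higher number from compound 3 to compound 4 (0.45 log units; beyond the scatter), so this change did not behave alike on the two cores: the same change on two cores in this assay, a 1.0-fold higher number (0.00 log units; within the scatter) from compound 1 to compound 2 and an at least 2.8-fold higher number (0.45 log units; beyond the scatter) from compound 3 to compound 4, at least 2.8-fold (0.45 log units) apart, beyond the scatter of two such steps

Compound 4 gives > 100 ug/mL, which is a limit of the assay and not a number: the limit of > 100 ug/mL in this assay, at which 1 of the 4 values shown sits.

These two pairs show that the outcome of this change differs between these two cores, but they do not show which difference between the cores is responsible or how the change would behave on a further core.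

The compounds shown leave open whether a carboxylic acid or a methyl group in the same place would follow the amino result on either core. They also leave open whether a dimethylamino group would do so.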